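The compounds below may be only part of what the source reports. "The series", "measured", "known", "first", "only" and "open" are said of these compounds alone.

Working notes on the series. Compound 1 `OC[C@]1(c2ccc(F)cc2)NC[C@H](O)[C@H]1O`, compound 2 `COc1ccc([C@]2(CO)NC[C@@H](O)[C@@H]2O)cc1` and compound 3 `Cc1ccc([C@@]2(CO)NC[C@H](O)[C@H]2O)cc1` share one core and differ only in the group on the aromatic carbon. In an assay on isolated protein for inhibition of lysosomal alpha-glucosidase (Homo sapiens), tested at 1000 uM (a higher number here means more inhibition at the concentration tested (going by the name of the read-out), a lower number less inhibition), compound 1 gives 8.3%, compound 2 gives 40.2% and compound 3 gives 45.9%. Compound 2 stands second of the three numbers: it sits within the scatter of compound 3 and beyond the scatter from compound 1. Among the compounds with values here, the only step between measured compounds is a number 37.6 percentage points higher from compound 1 to compound 3 (beyond the scatter); no step starting from compound 2 has been measured. Compound 4 `OC[C@@]1(c2ccccc2)NC[C@@H](O)[C@@H]1O` is the unmeasured member, reached from compound 2 by hydrogen in place of methoxy on an aromatic carbon. Within the data shown here, no measured step trades methoxy for hydrogen, so the change has no direct precedent. What the numbers show is that fluoro left compound 1 low while methoxy and methyl gave compound 2 and compound 3 moderate numbers; hydrogen, a group with no heavy atom, might land anywhere in that span, so a wide range is appropriate. The estimate for compound 4 in this assay is 30%, with a range from 8% to 52%. This estimate corresponds to an expected a number 10.2 percentage points lower from compound 2 to compound 4 (beyond the scatter).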

Compound 4, a percentage reported as inhibition, at one concentration (the size of the read-out at that concentration, not a potency): 35%
Compound 4: the middle estimate sits 5 percentage points below what was measured, and the stated range covers the measured number.
By their numbers in this assay, from the lowest: compound 1; then compounds 4, 2 and 3 (each within the scatter of the next, the first and the last beyond it).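

In this assay, hydrogen in place of methoxy on the aromatic carbon gives a number 5.2 percentage points lower from compound 2 to compound 4 (within the scatter), so at this position the read-out does not depend on methoxy, and the moderate number needs no heavy atom there. The printed values also set the low number of compound 1 (8.3%) apart from that of compound 4 (35%): with fluoro in place of hydrogen the numbers lie far apart, so among the four compounds the low number goes with fluoro alone and is not a feature of the shared core. No measurement on hand explains why fluoro stands apart from the other groups at this position.

The compounds shown leave open whether a chloro group, an amine or a carboxylic acid on this aromatic carbon would stay with the moderate numbers or fall toward compound 1, which would show whether fluoro is an isolated case. Going by these compounds, all of these numbers also come from a single tested concentration, so how the compounds compare in potency remains open.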